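Swapping the urea partner on the core of compound 2

This account rests on a few compounds, and the source may have more. Where it says the series, first, only, none or still open, it means among the compounds named here.

Measured so far:
compound 1 `O=C(Nc1ccccc1Cl)N1CCN(c2nc(-c3ccc4ccccc4n3)no2)CC1`: 140 nM
compound 2 `O=C(N1CCC(c2nc(-c3ccc4ccccc4n3)no2)CC1)N1CCCc2ccccc21`: 2300 nM

Both compounds were tested in a functional assay on Shh Light II cells (Mus musculus) for inhibition, read by a luciferase reporter; a higher number here means a weaker inhibitor, a lower number a stronger inhibitor. Of the two numbers shown, compound 2 gives the higher one, and compound 1 lies well below it, a gap beyond the usual scatter of this assay. Both share the same core; they differ in the group that sits on the carbonyl carbon and in the ring that carries it.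

Compound 3 `O=C(Nc1cccnc1Cl)N1CCC(c2nc(-c3ccc4ccccc4n3)no2)CC1` has not yet been measured. It keeps the ring that carries the carbonyl in compound 2 and changes only the partner on that carbonyl: (2-chloropyridin-3-yl)amino in place of 1,2,3,4-tetrahydroquinolin-1-yl on a carbonyl carbon. The group that leaves brings no hydrogen-bond donor or acceptor; the group that enters brings one of each.

Among the measured compounds shown here, with no measured pair that isolates this change, the expectation rests on compound 2 alone. From compound 2 to compound 3 a step of about a 5.8-fold lower number from compound 2 to compound 3 (0.76 log units; beyond the scatter) is expected, towards a lower number, clearly beyond the scatter. Compound 3 is therefore estimated at 400 nM, within a range of 100 nM to 1500 nM.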

Compound 3, half-maximal inhibitory concentration: 1600 nM
Estimate against measurement, compound 3: 4.0-fold (0.60 log units) below; measured number outside the range, above it.
By their numbers in this assay, from the lowest: compound 1; then compounds 3 and 2 (each within the scatter of the next).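

Putting (2-chloropyridin-3-yl)amino in place of 1,2,3,4-tetrahydroquinolin-1-yl on a carbonyl carbon gives, in this assay, a 1.4-fold lower number from compound 2 to compound 3 (0.16 log units; within the scatter), so the two partners cannot be told apart in this read-out. This is the first single change shown at this position, and it is a large one: a partner with no hydrogen-bond donor or acceptor gives way to one with one of each, and a group of two rings gives way to a group of one ring, yet the result stays within the scatter. On this core, then, the gain of a donor and an acceptor in this partner brings no measurable difference, and no measurement at hand offers an explanation for this result.

Compound 1 and compound 3 differ in more than one place, so their numbers cannot show which single change matters on the core. As far as these compounds go, it also remains open how other partners on this carbonyl, such as a plain phenylamino group or a morpholin-4-yl group, would read in this assay.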